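Trading the Phenyl of Compound 1 for Cyclohexenyl

The source may report more compounds than this note shows. Statements on the series, on what has been measured and on what is new or still open speak of the compounds shown alone.

Compound 1 `C=CS(=O)(=O)N1CCN(c2ncnc3sc(-c4ccccc4)cc23)CC1` is the parent of a small pair measured in a functional assay on MDA-MB-436 cells (Homo sapiens) for antiproliferative activity, read by MTT assay, with a stated time of 48 h; on this read-out higher numbers stand for weaker inhibition and lower numbers for stronger inhibition. In this assay, within the data shown here, compound 1 gives 21100 nM, the highest of the two numbers so far. Among the measured compounds shown here, its only measured neighbour is compound 2 `C=CS(=O)(=O)N1CCN(c2ncnc3sc(-c4ccc(C(F)(F)F)cc4)cc23)CC1`, which in this assay gives 7080 nM; the change is a 3.0-fold lower number from compound 1 to compound 2 (0.47 log units; beyond the scatter), brought about by trifluoromethyl in place of hydrogen on an aromatic carbon. Compound 3 `C=CS(=O)(=O)N1CCN(c2ncnc3sc(C4=CCCCC4)cc23)CC1` departs from compound 1 differently: cyclohex-1-en-1-yl in place of phenyl on an aromatic carbon. For the measured compounds named here, no measured step covers a swap of the aromatic ring itself, so the one step from compound 1 to compound 2 bears only loosely on it, showing that this position tolerates change of modest size. With nothing pointing firmly either way, the step from compound 1 to compound 3 is expected to be small, a 1.2-fold higher number from compound 1 to compound 3 (0.07 log units; within the scatter), within or near the scatter. Compound 3 is therefore estimated at 25000 nM, with a range from 8000 nM to 70000 nM.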

Compound 3, half-maximal inhibitory concentration: > 50000 nM
Compound 3 was reported as a limit; the forecaster's own chance of this, stated with the estimate: 15%; middle value at least 2.0-fold (0.30 log units) from the limit.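

Compound 3 is reported in this assay only as a limit of the assay, > 50000 nM in place of a number. Cyclohex-1-en-1-yl carries the same count of heavy atoms as phenyl, yet the swap gives an at least 2.3-fold higher number from compound 1 to compound 3 (0.37 log units; beyond the scatter) and so shows that this position, which had accepted an added trifluoromethyl on the phenyl, does not accept every six-membered carbon ring alike. Set against the trifluoromethyl compound, the same replacement gives an at least 7.0-fold higher number from compound 2 to compound 3 (0.84 log units; beyond the scatter) as a wider gap, and both steps are bounds that leave the full size of the loss unknown.

Going by these compounds, whether a pyridine ring or a thiophene ring at this position would hold the activity of compound 1 stays open. So does the effect on the number of a methoxy, an amine or a carboxylic acid on the phenyl of compound 1.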